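This account rests on a few compounds, and the source may have more. Where it says the series, first, only, none or still open, it means among the compounds named here.

Compound 1, `CC(C)(N)CN(C(=O)[C@@H]1C[C@H]1c1ccccc1)c1ccc(-c2ccccc2)cc1`: 1.4 nM
Compound 2, `CC[C@H](C)[C@H](N)CN(C(=O)[C@@H]1C[C@H]1c1cc(F)cc(F)c1)c1ccc(-c2ccccc2)cc1`: 960 nM

Both numbers come from a functional assay for agonist activity at G protein-coupled receptor 88 (Homo sapiens), read by HTRF and cAMP accumulation; a lower number here means that less compound is needed, a higher number that more compound is needed for the effect. Of the two, compound 2 gives the higher number, so more of it is needed for the same effect than of compound 1; only the two values themselves can be set side by side. Compound 3, `CC[C@H](C)[C@H](N)CN(C(=O)[C@@H]1C[C@H]1c1csc(C)n1)c1ccc(-c2ccccc2)cc1`, keeps the core of compound 2 and changes one group: 2-methyl-1,3-thiazol-4-yl in place of 3,5-difluorophenyl on a saturated ring carbon. Among the compounds with values here, no measured pair shows this kind of exchange, so nothing anchors a direction. The step of a 1.2-fold lower number from compound 2 to compound 3 (0.08 log units; within the scatter) is expected to be small and could fall either way. Compound 3 is estimated at 800 nM, within a range from 200 nM to 4000 nM.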

Compound 3, half-maximal effective concentration: 1500 nM
For compound 3 the middle estimate is 1.9-fold (0.27 log units) below the measured one; measured number inside the range.
By their numbers in this assay, from the lowest: compound 1; then compounds 2 and 3 (each within the scatter of the next).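

In this assay, the step of a 1.6-fold higher number from compound 2 to compound 3 (0.19 log units; within the scatter) shows that, on this saturated ring carbon, a five-membered aromatic ring with 2 hetero atoms can replace a six-membered aromatic ring of carbon only without a change beyond the scatter. The two hydrogen-bond acceptors that enter with 2-methyl-1,3-thiazol-4-yl therefore leave the number where it was. Nothing measured here gives a reason for this. Still open, from the compounds shown here alone, is how a pyridinyl ring or a cyclohexyl group would read at this position on the same core.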